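Sulfone to Hydroxypyrrolidine Sulfonamide: Expected Stability Shift

The source may report more compounds than this note shows. Statements on the series, on what has been measured and on what is new or still open speak of the compounds shown alone.

In an ADME assay on microsomes from liver (Mus musculus) for metabolic stability, read by LC-MS, using NADPH, with a stated time of 30 min, tested at 0.1 uM (on this read-out lower numbers stand for a less stable compound and higher numbers for a more stable compound), compound 3 `O=S(=O)(CCO)c1cccc(-c2ccc3nccc(-c4ccncc4)c3n2)c1` gives 52%, the highest of the three numbers seen. Compound 1 `O=S(=O)(NCC1COC1)c1cccc(-c2ccc3nccc(-c4ccncc4)c3n2)c1` gives 19% and compound 2 `NS(=O)(=O)c1ccc(-c2ccc3nccc(-c4ccncc4)c3n2)cc1` gives 13%. Among the measured compounds shown here, the one measured step between neighbours, a number 33 percentage points higher from compound 1 to compound 3 (beyond the scatter), is large. Compound 4 `O=S(=O)(c1cccc(-c2ccc3nccc(-c4ccncc4)c3n2)c1)N1CC[C@H](O)C1` differs from compound 3 by 3-hydroxypyrrolidin-1-yl in place of 2-hydroxyethyl on a sulfonyl sulfur. This puts a nitrogen back on the sulfonyl sulfur, as in compound 1 and compound 2, so that step read in reverse bears on it, and a fall is expected, although the new group matches neither of those compounds. For compound 4 the expected change is a number 27 percentage points lower from compound 3 to compound 4 (beyond the scatter), with an estimate of 25%, between 10% and 45%.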

Compound 4, percent of the compound remaining: 12%
Compound 4: middle estimate off by 13 percentage points, on the high side; measured number inside the range.
By their numbers in this assay, from the lowest: compounds 4, 2 and 1 (each within the scatter of the next); then compound 3.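

In this assay, the change gives a number 40 percentage points lower from compound 3 to compound 4 (beyond the scatter). Both groups carry a hydroxy group, so that group alone does not hold the number up on this sulfonyl sulfur. Against ((oxetan-3-yl)methyl)amino, the change gives a number 7 percentage points lower from compound 1 to compound 4 (within the scatter), so these two nitrogen-linked groups read alike here.

Nothing measured here explains the fall. On these data alone, whether a plain methyl or a longer carbon chain ending in a carboxylic acid on the sulfonyl sulfur would keep the number of compound 3 stays open.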